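This account rests on a few compounds, and the source may have more. Where it says the series, first, only, none or still open, it means among the compounds named here.

Measured in an ADME assay on microsomes from liver (Rattus norvegicus) for metabolic stability; a lower number here means that the compound disappears faster, a higher number that the compound lasts longer:
- Compound 1 `CC(C)C(CC1C(=O)NC(=O)N1C)c1ccc(-c2ccc3cccc(F)c3c2)[nH]c1=O`: < 0.0667 h
- Compound 2 `O=C1NC(=O)/C(=C/C(c2ccc(-c3ccc4cccc(F)c4c3)[nH]c2=O)C2CC2)O1`: > 3 h

Both values are limits, not numbers. Compound 1 stands at the low end of the two: the limit of < 0.0667 h in this assay, at which 1 of the 2 values shown sits. Compound 3 `CC(C)C(/C=C1\SC(=O)NC1=O)c1ccc(-c2ccc3cccc(F)c3c2)[nH]c1=O`, not yet measured, differs from compound 1 as follows: a group of 8 heavy atoms (4 carbon, 1 nitrogen, 2 oxygen, 1 sulfur; one five-membered non-aromatic ring with 2 hetero atoms) in place of a group of 9 heavy atoms (5 carbon, 2 nitrogen, 2 oxygen; one five-membered non-aromatic ring with 2 hetero atoms), on a saturated chain carbon bound to an aromatic carbon and a saturated chain carbon. Among the compounds with values here, no measured step between compounds differing in one place is available to size this change. Compound 2 lacks the (3-methyl-2,5-dioxoimidazolidin-4-yl)methyl group, and its limit of > 3 h is the only basis for an upward expectation in this assay. The expected at least 7.4-fold higher number from compound 1 to compound 3 (0.87 log units; beyond the scatter) is therefore large but uncertain. For compound 3 the estimate is 0.5 h, with an expected range of 0.08 h to 3 h.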

Compound 3, half-life: 2.62 h
For compound 3 the middle estimate is 5.2-fold (0.72 log units) below the measured one, and the stated range covers the measured number.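

In this assay, the group of 8 heavy atoms with one sulfur in place of the (3-methyl-2,5-dioxoimidazolidin-4-yl)methyl group gives an at least 39-fold higher number from compound 1 to compound 3 (1.59 log units; beyond the scatter). Compound 1 holds a limit, not a number: < 0.0667 h. This single exchange on the saturated chain carbon is thus enough to lift compound 3 to a measured 2.62 h, so the group at this place strongly affects the half-life. On these data alone, whether the sulfur, the extra double bond or the ring as a whole carries the step stays open. As far as these compounds go, how an amine or a carboxylic acid would fare at this place also stays open.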